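Aryl variation in a shared core: expectation for compound 4

The source may report more compounds than this note shows. Statements on the series, on what has been measured and on what is new or still open speak of the compounds shown alone.

compound 1 `Nc1cc(-c2nc(C(c3ccc(F)cc3)c3ccc(F)cc3)sc2CC(=O)O)cc(F)n1` — 30%
compound 2 `NS(=O)(=O)c1cccc(-c2nc(C(c3ccc(F)cc3)c3ccc(F)cc3)sc2CC(=O)O)c1` — 55%
compound 3 `O=C(O)Cc1sc(C(c2ccc(F)cc2)c2ccc(F)cc2)nc1-c1ccoc1` — 80%

In an in vitro functional assay on HEK285-7 cells for antagonist activity at prostaglandin D2 receptor 2 (Homo sapiens), read by BRET and beta-arrestin recruitment (a higher number here means a larger maximal response, a lower number a smaller maximal response), compound 3 gives 80%, the highest of the three numbers. Compound 2 gives 55% and compound 1 gives 30%. The three measured steps, a number 25 percentage points higher from compound 1 to compound 2 (beyond the scatter), a number 50 percentage points higher from compound 1 to compound 3 (beyond the scatter) and a number 25 percentage points higher from compound 2 to compound 3 (beyond the scatter), all exchange the whole group on the aromatic carbon of the shared core, and each lies beyond the scatter; the furan-3-yl compound 3 sits at the top.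

Compound 4 `O=C(O)Cc1sc(C(c2ccc(F)cc2)c2ccc(F)cc2)nc1-c1ccco1` differs from compound 3 by furan-2-yl in place of furan-3-yl on an aromatic carbon. Within the data shown here, no measured step exchanges one furanyl isomer for another, so none bears directly on this change; the measured steps show only that the group at this position can move the maximal response widely, and the smallest of them was a number 25 percentage points higher from compound 2 to compound 3 (beyond the scatter). A step smaller than that is expected, most likely toward a lower number. The maximal response of compound 4 is estimated at 70%, with a range from 45% to 90%, which means an expected step of a number 10 percentage points lower from compound 3 to compound 4 (within the scatter).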

Compound 4, largest response reached (reported as efficacy), in percent of the reference or control that the assay uses: 80%
Estimate against measurement, compound 4: 10 percentage points below, and the stated range covers the measured number.
By their numbers in this assay, from the lowest: compound 1; then compound 2; then compounds 3 and 4 (each within the scatter of the next).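

In this assay, furan-2-yl in place of furan-3-yl on this aromatic carbon gives no change at the digits printed from compound 3 to compound 4 (within the scatter), so the two furanyl isomers cannot be told apart here, although their point of attachment differs. Compound 4 stands apart from the other two aryl groups just as compound 3 does, with a number 25 percentage points higher from compound 2 to compound 4 (beyond the scatter) and a number 50 percentage points higher from compound 1 to compound 4 (beyond the scatter). Nothing available accounts for the two isomers reading alike.

From the compounds shown here alone, whether the ring oxygen matters at this position remains open, and a thiophen-2-yl or thiophen-3-yl group would address that. Also open, going by these compounds, is whether the smaller responses of compound 1 and compound 2 go with their six-membered rings or with the amino and sulfamoyl groups on them, a question that an unsubstituted phenyl group would address.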